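The compounds below may be only part of what the source reports. "The series", "measured", "known", "first", "only" and "open" are said of these compounds alone.

Measured so far in an ADME assay for permeability, using PAMPA, at pH 7.4; on this read-out higher numbers stand for higher permeability and lower numbers for lower permeability:
compound 1 `Cc1cc(NC(=O)Nc2ccc(N)cc2)c2ccccc2n1` gives 530 10^-6 cm/s;
compound 2 `Cc1cc(NC(=O)Nc2ccc(O)cc2)c2ccccc2n1` gives 3 10^-6 cm/s;
compound 3 `COC(=O)c1ccc(NC(=O)Nc2cc(C)nc3ccccc23)cc1` gives 448 10^-6 cm/s.

Compound 3 stands second highest of these three numbers. The nearest value is close: a 1.2-fold lower number from compound 1 to compound 3 (0.07 log units; within the scatter). The furthest is far away: a 150-fold higher number from compound 2 to compound 3 (2.17 log units; beyond the scatter). Compound 4 `CSc1ccc(NC(=O)Nc2cc(C)nc3ccccc23)cc1` differs from compound 3 in one place: methylsulfanyl in place of methoxycarbonyl on an aromatic carbon. Two measured steps change this same position. One, a 1.2-fold lower number from compound 1 to compound 3 (0.07 log units; within the scatter), stayed within the scatter; the other, a 150-fold higher number from compound 2 to compound 3 (2.17 log units; beyond the scatter), was large. Among the measured compounds shown here, no measured step involves methylsulfanyl, so its effect is not known from these data. Both groups without a hydrogen-bond donor gave high numbers, and methylsulfanyl also brings none, so the expected step is a 1.0-fold higher number from compound 3 to compound 4 (0.00 log units; within the scatter), within the scatter. Compound 4 is estimated at 450 10^-6 cm/s, in a range from 200 10^-6 cm/s to 950 10^-6 cm/s.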

Compound 4, apparent permeability: 473 10^-6 cm/s
The estimate for compound 4 lay 1.1-fold (0.02 log units) below the measured number; the measured number falls inside the stated range.
By their numbers in this assay, from the lowest: compound 2; then compounds 3, 4 and 1 (each within the scatter of the next).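

Methylsulfanyl gives a third group at this position that matches amino and methoxycarbonyl in this assay, with both comparisons within the scatter (a 1.1-fold higher number from compound 3 to compound 4 (0.02 log units; within the scatter); a 1.1-fold lower number from compound 1 to compound 4 (0.05 log units; within the scatter)), while the step from hydroxy is large (a 160-fold higher number from compound 2 to compound 4 (2.20 log units; beyond the scatter)). Among these four groups, hydroxy alone stands apart, and compound 2 is the one exception to otherwise matching numbers. No measured evidence here explains that difference.

Still open, going by these compounds, is whether a carboxylic acid or a longer chain at this position would match compound 4 or compound 2.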